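Mirror Image of the Most Active Urea in the Rice Assay

The compounds below may be only part of what the source reports. "The series", "measured", "known", "first", "only" and "open" are said of these compounds alone.

The study compares two ureas in an ADME assay on the whole organism with Oryza sativa as the target, tested at 10 uM; on this read-out lower numbers stand for a stronger effect and higher numbers for a weaker effect at the one concentration tested. Compound 1 `C[C@H](NC(=O)Nc1ccccc1F)c1ccccc1` gives 65% there, while compound 2 `C[C@@H](NC(=O)Nc1ccc(F)cc1F)c1ccccc1` gives 93% in this assay. On these two numbers compound 2 stands highest, and its nearest neighbour, compound 1, lies a good way below it, a gap beyond the usual scatter. Among the measured compounds shown here, the two differ in more than one place, so no single step between them is known.

Compound 3 `C[C@H](NC(=O)Nc1ccc(F)cc1F)c1ccccc1` has not yet been measured in this assay. Its relation to compound 2 is this: the two compounds have the same atoms and bonds and differ only in configuration as drawn: 1 of 1 stereo elements differ; a stereocentre at a saturated chain carbon is drawn R in compound 2 and S in compound 3. Nothing measured isolates the effect of configuration alone. The expected step of a number 13 percentage points lower from compound 2 to compound 3 (beyond the scatter) in this assay is of modest size downward, though a result within the scatter would not surprise. Compound 3 is expected to give about 80%, within a range from 55% to 100%.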

Compound 3, a percentage reported as activity, at one concentration (the size of the read-out at that concentration, not a potency): 99%
The estimate for compound 3 lay 19 percentage points below the measured number, within the range that was stated.
By their numbers in this assay, from the lowest: compound 1; then compounds 2 and 3 (each within the scatter of the next).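

Among the compounds shown here, the pair isolates configuration at this stereocentre, which the earlier compounds could not do: the fact that compounds 2 and 3 differ only in the configuration as drawn. In this assay the change from R to S gives a number 6 percentage points higher from compound 2 to compound 3 (within the scatter), so at this one concentration the two mirror images cannot be told apart, and with the added fluoro present the drawn configuration at the saturated chain carbon shows no effect beyond the scatter. The other new step keeps the drawn configuration fixed and isolates fluoro in place of hydrogen on an aromatic carbon, giving a number 34 percentage points higher from compound 1 to compound 3 (beyond the scatter), a large shift towards a weaker effect that compound 2 alone could not attribute to that change.

As far as these compounds go, it remains open whether configuration would matter in the absence of this added fluoro. From the compounds shown here alone, it is equally open whether a chloro or methoxy group in its place would weaken the effect as the fluoro does.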